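This account rests on a few compounds, and the source may have more. Where it says the series, first, only, none or still open, it means among the compounds named here.

Three compounds share one core and differ only in the group carried on the ring nitrogen. Compound 1 `Cc1nc(S(C)(=O)=O)ccc1Oc1ncnc(OC2CCN(C(=O)OC(C)(C)C#N)CC2)c1F` gives 1320 nM in a functional assay on isolated protein for inhibition of Glucose-dependent insulinotropic receptor (Rattus norvegicus), read by HTRF and cAMP accumulation; on this read-out lower numbers stand for an effect already at smaller amounts and higher numbers for an effect only at larger amounts of compound. Compound 2 `Cc1nc(S(C)(=O)=O)ccc1Oc1ncnc(OC2CCN(C(=O)SC3(C)CC3)CC2)c1F` gives 166 nM in this assay, and compound 3 `Cc1nc(S(C)(=O)=O)ccc1Oc1ncnc(OC2CCN(C(=S)OC3(C)CC3)CC2)c1F` gives 48.8 nM in this assay. Compound 3 thus carries the lowest number of the three, with a 3.4-fold lower number from compound 2 to compound 3 (0.53 log units; beyond the scatter) and a 27-fold lower number from compound 1 to compound 3 (1.43 log units; beyond the scatter) both beyond the scatter.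

Compound 4 `CCC(F)(F)C(=O)N1CCC(Oc2ncnc(Oc3ccc(S(C)(=O)=O)nc3C)c2F)CC1` has not yet been measured in this assay. It differs from compound 3 by a group of 7 heavy atoms (4 carbon, 1 oxygen, 2 fluorine; no ring) in place of a group of 7 heavy atoms (5 carbon, 1 oxygen, 1 sulfur; one three-membered non-aromatic ring of carbon only), on an amine nitrogen in a ring.

All three measured steps sit on this same nitrogen, so all bear on the new step. Going by the values given here, the step of an 8.0-fold lower number from compound 1 to compound 2 (0.90 log units; beyond the scatter) and the step of a 27-fold lower number from compound 1 to compound 3 (1.43 log units; beyond the scatter) show that exchanging the group on this nitrogen can move the number a great deal, and the one measured group without a ring, in compound 1, gives the highest number. Compound 4 also carries a group without a ring, though a different one. The expected step is therefore a 6.1-fold higher number from compound 3 to compound 4 (0.79 log units; beyond the scatter), an increase in the number, with wide uncertainty. For compound 4 the estimate in this assay is 300 nM, expected to fall between 80 nM and 1200 nM.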

Compound 4, half-maximal effective concentration: 69.2 nM
Compound 4: middle estimate off by 4.3-fold (0.64 log units), on the high side; the measured number lies below the stated range.
By their numbers in this assay, from the lowest: compounds 3 and 4 (each within the scatter of the next); then compound 2; then compound 1.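

Compound 4 shows that the group on this amine nitrogen does not need a ring to reach the low end of the series in this assay: with a 1.4-fold higher number from compound 3 to compound 4 (0.15 log units; within the scatter), compounds 3 and 4 cannot be told apart, even though 1,1-difluoropropyl has neither the three-membered ring nor the sulfur of the group it replaces. Ringless groups also need not give high numbers, as a 19-fold lower number from compound 1 to compound 4 (1.28 log units; beyond the scatter) separates two ringless groups on the same carbonyl carbon, so what matters here is which ringless group is present, not merely that the ring is absent. Compound 4 also goes beyond the sulfur-bearing, ring-bearing group of compound 2, with a 2.4-fold lower number from compound 2 to compound 4 (0.38 log units; beyond the scatter), but no measurement available here explains any of these differences.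

The compounds shown leave open what the two fluorines contribute, since the comparison that would test this is a plain propyl group on the same carbonyl carbon. They also leave open how the number responds to chain length, for example with a longer chain such as 1,1-difluorobutyl.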